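The compounds below may be only part of what the source reports. "The series", "measured", "known", "first", "only" and "open" are said of these compounds alone.

Compound 1 `CN(C)C(=O)c1ccc2c(c1)/C(=C(/Nc1ccc(CN3CCCCC3)cc1)c1ccccc1)C(=O)N2` gives the lower of the two measured numbers in an assay on isolated protein for inhibition of ribosomal protein S6 kinase alpha-5 (Homo sapiens), tested at 1 uM; on this read-out lower numbers stand for less inhibition and higher numbers for more inhibition at the one concentration tested (going by the name of the read-out): in this assay compound 1 gives 36%. Its nearest neighbour, compound 2 `CCNC(=O)c1ccc2c(c1)NC(=O)/C2=C(\Nc1ccc(CN(C)C)cc1)c1ccccc1`, gives 104% in this assay, a number standing well above compound 1 by a gap that lies beyond the usual scatter of repeated measurements. Compound 2 differs from compound 1 in more than one place, so it offers no clean single change from which a step can be read.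

Compound 3 `O=C1Nc2ccccc2/C1=C(/Nc1ccc(CN2CCCCC2)cc1)c1ccccc1` is the unmeasured analogue. Compared with compound 1, the change is hydrogen in place of dimethylcarbamoyl on an aromatic carbon. Among the compounds with values here, with no measured pair isolating this change, the direction of its effect is uncertain; the expected step is a number 4 percentage points higher from compound 1 to compound 3 (within the scatter), which would stay within the scatter rather than mark a clear shift in either direction. On this basis compound 3 is expected to show about 40% in this assay, with a range from 10% to 75%.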

Compound 3, a percentage reported as inhibition, at one concentration (the size of the read-out at that concentration, not a potency): 8%
Compound 3: the middle estimate sits 32 percentage points above what was measured; the whole stated range lies above it.
By their numbers in this assay, from the lowest: compound 3; then compound 1; then compound 2.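

Within the data shown here, the step gives the first clean reading at this position: a number 28 percentage points lower from compound 1 to compound 3 (beyond the scatter) in this assay. With everything else held the same, replacing dimethylcarbamoyl with hydrogen on this aromatic carbon, meta to a fused ring and para to a fused ring, therefore lowers inhibition at the one concentration tested by more than the usual scatter, so the position is not indifferent to what it carries. Nothing available here accounts for this step, which rests on a single pair of compounds.

What the compounds shown leave open is whether the carbonyl, the two methyl groups on the nitrogen or the whole dimethylcarbamoyl matters here, and how a primary carboxamide, a carboxylic acid or a methoxy group at the same carbon would read in this assay. They also leave open how much of the higher number of compound 2, at 104%, belongs to its amide and how much to its other differences, since compound 2 differs from compound 1 in more than one place.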